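Cytotoxicity notes on a piperidine amide series

The compounds below may be only part of what the source reports. "The series", "measured", "known", "first", "only" and "open" are said of these compounds alone.

Measured so far:
- Compound 1, `O=C(Nc1ccc(Cl)cc1)C1CCCN(C(=O)c2cccc(-c3nccs3)c2)C1`: 32%
- Compound 2, `CC(C)(C)OC(=O)c1cccc(NC(=O)C2CCCN(C(=O)c3cc(C(F)(F)F)cc(C(F)(F)F)c3)C2)c1`: 0%

In an ADME assay on PC-3 cells (Homo sapiens) for cytotoxicity, read by WST assay, tested at 100 uM (on this read-out lower numbers stand for less inhibition and higher numbers for more inhibition at the one concentration tested (going by the name of the read-out)), compound 1 gives 32%, while compound 2 gives 0%. Of the two numbers, compound 2 stands lowest; the nearest compound is compound 1, whose number lies higher by a gap beyond the usual scatter of this assay.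

Compound 3, `O=C(Nc1cccc(Cc2ccccc2)c1)C1CCCN(C(=O)c2cc(C(F)(F)F)cc(C(F)(F)F)c2)C1`, has not yet been tested in this assay. It derives from compound 2 by a single change: benzyl in place of tert-butoxycarbonyl on an aromatic carbon. The change sits on an aromatic carbon of a six-membered aromatic ring of carbon only, meta to a large group; the rest of the shared core is untouched.

Going by the values given here, no measured pair in the set isolates this change, so its size is unknown. Only two data points exist. For compound 3 the step of a number 15 percentage points higher from compound 2 to compound 3 (beyond the scatter) is expected to be small and upward, if anything. Compound 3 is estimated to give 15% in this assay, within a range from 0% to 45%.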

Compound 3, a percentage reported as inhibition, at one concentration (the size of the read-out at that concentration, not a potency): 0%
The estimate for compound 3 lay 15 percentage points above the measured number, within the range that was stated.
By their numbers in this assay, from the lowest: compounds 2 and 3 (each within the scatter of the next); then compound 1.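

In this assay, going by these compounds alone, the pair of compound 2 and compound 3 isolates one change for the first time, benzyl in place of tert-butoxycarbonyl on an aromatic carbon, meta to a large group, and gives no change at the digits printed from compound 2 to compound 3 (within the scatter) at this position. Exchanging a group with a double bond outside aromatic rings and hydrogen-bond acceptors for one with a six-membered aromatic ring of carbon only and no hydrogen-bond acceptors therefore does not separate the two compounds on this read-out. No measurement available here bears on the reason for this result.

As far as these compounds go, whether any group at this position can move the read-out away from the shared value of this pair remains open. An amine or a carboxylic acid on this aromatic carbon, or a longer chain carrying either group, would test this.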